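A few compounds are considered here, and "the series" means these few. Any claim that something is new, unique, unknown or untested is made for them only; others in the source may bear on it.

The measured compounds:
compound 1 `Cc1c(/N=C/c2cccc(O)c2)c(=O)n(-c2ccccc2)n1C`; in a functional assay on DLD-1 cells (Homo sapiens) for cytotoxicity, read by MTT assay, with a stated time of 72 h (a higher number here means a weaker inhibitor, a lower number a stronger inhibitor), compound 1 gives 372000000 nM
compound 2 `Cc1c(/N=C/c2ccc(O)cc2)c(=O)n(-c2ccccc2)n1C`; in this assay compound 2 gives 646000000 nM

On these two numbers compound 2 stands beside compound 1 rather than apart from it: the step of a 1.7-fold higher number from compound 1 to compound 2 (0.24 log units; within the scatter) is the only one measured, and it lies within the scatter, so the two compounds cannot be ranked against each other.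

Compound 3 `Cc1c(/N=C/c2cccc(Cl)c2)c(=O)n(-c2ccccc2)n1C` is the next compound, not yet measured. It differs from compound 2 in one place: 3-chlorophenyl in place of 4-hydroxyphenyl on a carbon with a double bond to nitrogen. Among the measured compounds shown here, no measured step speaks directly to this change. For the measured compounds named here, the single step on record, from compound 1 to compound 2, only moves the hydroxyl to another position on the same ring and does not exchange it for chlorine, and it was itself within the scatter. Going by the values given here, with the hydroxyl gone and a chlorine in its place there is no measured precedent to lean on, so the expectation is a step of a 1.3-fold lower number from compound 2 to compound 3 (0.11 log units; within the scatter), that is, nothing beyond the scatter in either direction. Compound 3 is therefore estimated at 500000000 nM in this assay, with a range from 120000000 nM to 2000000000 nM.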

Compound 3, half-maximal inhibitory concentration: 724000000 nM
The estimate for compound 3 lay 1.4-fold (0.16 log units) below the measured number; low and high end bracket the measured number.
By their numbers in this assay, from the lowest: compounds 1, 2 and 3 (each within the scatter of the next).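

In this assay the exchange of 4-hydroxyphenyl for 3-chlorophenyl on the carbon with a double bond to nitrogen comes out as a 1.1-fold higher number from compound 2 to compound 3 (0.05 log units; within the scatter) and so, unlike the earlier step, which only moved the hydroxyl around the ring, it shows the hydroxyl being given up altogether without a step beyond the scatter. The comparison that changes only chloro in place of hydroxy on an aromatic carbon reads as a 1.9-fold higher number from compound 1 to compound 3 (0.29 log units; within the scatter) and likewise stays within the scatter, so among these three compounds a ring with 0 hydrogen-bond donors and 0 hydrogen-bond acceptors cannot be told apart from one that carries a hydroxyl. No measurement at hand offers an explanation for this result.

All three compounds remain unranked, and these numbers cannot say whether chlorine and hydroxyl are simply equivalent here or whether this ring has little bearing on the read-out at all. Going by these compounds, whether an amine, a carboxylic acid or a longer chain such as butyl on this ring would produce a step beyond the scatter remains open.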